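This account rests on a few compounds, and the source may have more. Where it says the series, first, only, none or still open, it means among the compounds named here.

Working notes on the series. Three compounds have been run in a functional assay on T47D cells (Homo sapiens) for inhibition, read by sulforhodamine B assay, with a stated time of 48 h; a higher number here means a weaker inhibitor of growth, a lower number a stronger inhibitor of growth. Compound 1 `O=C(/C(=C/c1ccccc1)CCl)c1ccccc1` gives 18000 nM in this assay. Compound 2 `O=C(OC/C(=C\c1ccccc1[N+](=O)[O-])C(=O)c1ccccc1)c1ccccc1` gives 16000 nM. Compound 3 `C=C(C/C(=C\c1ccccc1)C(=O)c1ccccc1)C(=O)c1ccccc1` gives 15000 nM, the lowest of the three numbers, but its gap to compound 2 and its gap to compound 1 both sit within the scatter, so the three are not separated by this assay and no order among them can be read. Among the measured compounds shown here, no single-point step between measured compounds exists in the set, so nothing measured tells how a small change on the shared core moves the number.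

Compound 4 `C=C(C/C(=C\c1ccc(F)cc1)C(=O)c1ccccc1)C(=O)c1ccccc1` has not been measured. It differs from compound 3 by fluoro in place of hydrogen on an aromatic carbon of a six-membered aromatic ring of carbon only, para to a large group; read one bond further out, phenyl becomes 4-fluorophenyl. For the measured compounds named here, with no measured step to lean on, the expectation is a step of no size beyond the scatter, in no set direction. For compound 4 the estimate is 14000 nM, with a range from 6000 nM to 35000 nM, which amounts to an expected step of a 1.1-fold lower number from compound 3 to compound 4 (0.03 log units; within the scatter).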

Compound 4, concentration for 50% growth inhibition: 15000 nM
Compound 4: the middle estimate sits 1.1-fold (0.03 log units) below what was measured; the range from low to high includes it.
By their numbers in this assay, from the lowest: compounds 3, 4, 2 and 1 (each within the scatter of the next).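

In this assay the series now has its first single-point step, which reads no change at the digits printed from compound 3 to compound 4 (within the scatter) for fluoro in place of hydrogen on an aromatic carbon, para to a large group. Among the compounds shown here, the earlier compounds held no such step, so this is the first measured sign that the shared core can take phenyl to 4-fluorophenyl at this place with the number staying within the scatter. The reading covers this one substituent at this one place, on the background of compound 3 and in this one growth assay, and no measurement at hand bears on why the number holds.

What the compounds shown leave open is whether this place is insensitive to substitution in general or only to this small atom, since a single fluoro cannot tell the two apart, and a larger or charged group such as methoxy, an amine or a carboxylic acid at the same place would be needed to decide it. Also open is how the other phenyl rings of the shared core respond, as no step on them stands among these compounds.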